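The source may report more compounds than this note shows. Statements on the series, on what has been measured and on what is new or still open speak of the compounds shown alone.

Measured compounds and their values in a functional assay on LOX IMVI cells (Homo sapiens) for cytotoxicity, read by sulforhodamine B assay, with a stated time of 48 h, tested at 1 uM; a higher number here means a weaker effect of the compound at the concentration tested, a lower number a stronger effect:
compound 1, `COc1cc(-c2cc(/C=C/C(=O)c3ccc(N)cc3)[nH]n2)cc(OC)c1OC`: 83%
compound 2, `COc1cc(-c2cc(/C=C/C(=O)c3ccc(Cl)c(Cl)c3)[nH]n2)cc(OC)c1OC`: 88%
compound 3, `COc1ccc(C(=O)/C=C/c2cc(-c3cc(OC)c(OC)c(OC)c3)n[nH]2)cc1`: 85%

Compound 3 stands second highest of the three numbers, but every gap to the others is small: the step of a number 2 percentage points higher from compound 1 to compound 3 (within the scatter) and the step of a number 3 percentage points lower from compound 2 to compound 3 (within the scatter) both lie within the scatter, so the three compounds cannot be told apart on these data.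

Compound 4, `COc1cc(-c2cc(/C=C/C(=O)c3ccc(F)c(F)c3)[nH]n2)cc(OC)c1OC`, differs from compound 3 in one place: 3,4-difluorophenyl in place of 4-methoxyphenyl on a carbonyl carbon. The step that bears on this is a number 3 percentage points lower from compound 2 to compound 3 (within the scatter), where a dihalogenated phenyl gave way to the same 4-methoxyphenyl; it was within the scatter, as was a number 5 percentage points higher from compound 1 to compound 2 (within the scatter). Running the related swap back the other way is therefore expected to give no step beyond the scatter, a number 2 percentage points higher from compound 3 to compound 4 (within the scatter). Compound 4 is estimated to give 87% in this assay, with a range from 76% to 98%.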

Compound 4, a percentage reported as activity, at one concentration (the size of the read-out at that concentration, not a potency): 92%
Compound 4: middle estimate off by 5 percentage points, on the low side; the measured number falls inside the stated range.
By their numbers in this assay, from the lowest: compounds 1, 3, 2 and 4 (each within the scatter of the next).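

In this assay, 3,4-difluorophenyl on a carbonyl carbon cannot be told apart from the other three groups, with a number 7 percentage points higher from compound 3 to compound 4 (within the scatter) and a number 4 percentage points higher from compound 2 to compound 4 (within the scatter) and also a number 9 percentage points higher from compound 1 to compound 4 (within the scatter). Even the largest of these steps stays within the scatter, so a fourth group at this position still separates no pair of compounds. Nothing available here explains these results.

The compounds shown leave open whether a quite different group on this carbonyl carbon, such as a carboxylic acid or a longer chain, would give a step beyond the scatter.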